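A few compounds are considered here, and "the series" means these few. Any claim that something is new, unique, unknown or untested is made for them only; others in the source may bear on it.

Compound 1 `CCc1ccccc1N(CC(=O)NCc1ccc(OC)c(OC)c1)S(=O)(=O)c1ccc(C)cc1` gives 25.1 nM in an assay on CHO cells for displacement of a labelled ligand from prostaglandin E2 receptor EP1 subtype (Homo sapiens); a higher number here means a weaker inhibitor, a lower number a stronger inhibitor.
Compound 2 `CCc1ccccc1N(CC(=O)NCc1cccc(OC)c1)S(=O)(=O)c1ccc(C)cc1` gives 79.4 nM in this assay.
Compound 3 `CCc1ccccc1N(CC(=O)NCc1ccc(Cl)cc1)S(=O)(=O)c1ccc(C)cc1` gives 10 nM in this assay.

Compound 3 stands lowest of the three numbers in this assay, which here means the strongest inhibitor. Both steps leading to it lie beyond the scatter: a 2.5-fold lower number from compound 1 to compound 3 (0.40 log units; beyond the scatter) and a 7.9-fold lower number from compound 2 to compound 3 (0.90 log units; beyond the scatter). The third measured step, a 3.2-fold higher number from compound 1 to compound 2 (0.50 log units; beyond the scatter), is also beyond the scatter. All three steps change only the group on the saturated chain carbon bound to the amide-type nitrogen; the rest of the core is shared.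

Compound 4 `Cc1ccc(S(=O)(=O)N(CC(=O)NCc2ccc(Cl)cc2)c2cccnc2C)cc1` departs from compound 3 at a different place, the sulfonamide nitrogen: 2-methylpyridin-3-yl in place of 2-ethylphenyl on a sulfonamide nitrogen. Among the measured compounds shown here, none of the measured steps touches this part of the molecule, so the numbers give no indication of direction or size for this change. Without any bearing step, the expectation for this assay is a change that stays within the usual scatter, with wide uncertainty, a 2.0-fold higher number from compound 3 to compound 4 (0.30 log units; within the scatter). Compound 4 is therefore estimated to give about 20 nM in this assay, with a range from 5 nM to 80 nM reflecting how little the measured compounds say about this site.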

Compound 4, inhibition constant: 200 nM
Compound 4: the middle estimate sits 10-fold (1.00 log units) below what was measured; measured number above the stated range.
By their numbers in this assay, from the lowest: compound 3; then compound 1; then compound 2; then compound 4.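

On the sulfonamide nitrogen, the group turns out to matter a great deal in this assay: putting 2-methylpyridin-3-yl in place of 2-ethylphenyl gives a 20-fold higher number from compound 3 to compound 4 (1.30 log units; beyond the scatter), a larger step than any of the three seen among the groups on the amide side. This single swap alters more than one feature at once, since a ring of carbon only gives way to a ring holding one nitrogen, a hydrogen-bond acceptor is gained, and ethyl is replaced by methyl, so the step cannot be assigned to any one of these. No supporting measurement is available to explain the size of this step.

The compounds shown leave open whether the ring nitrogen or the shorter methyl accounts for the step, a question that 2-methylphenyl or 2-ethylpyridin-3-yl on the sulfonamide nitrogen could help to settle. They also leave open how a longer chain, such as 2-propylphenyl, would fare there, and whether the order among the groups on the amide side would hold with another group on the sulfonamide nitrogen.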